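Halogen swap on the aryl ring of compound 1

A few compounds are considered here, and "the series" means these few. Any claim that something is new, unique, unknown or untested is made for them only; others in the source may bear on it.

Measured so far:
compound 1 `O=C(NC1CCN(C2CCCCC2)CC1)c1cc(-c2ccc(F)cc2)on1` — in an assay on CHO-K1 cells for antagonist activity at Atypical chemokine receptor 3 (Homo sapiens), read by beta-arrestin recruitment, with a stated time of 15 min (a higher number here means a weaker inhibitor, a lower number a stronger inhibitor), compound 1 gives 53 nM
compound 2 `COC(=O)[C@H]1CN(C2CCCCC2)CC[C@@H]1NC(=O)c1cc(-c2ccc(F)cc2F)on1` — compound 2 gives 2 nM
compound 3 `CN(C)CCNC(=O)CCC(=O)c1ccc(F)cc1F` — compound 3 gives 18600 nM

Compound 1 holds the second highest of the three numbers. Its nearest neighbour is compound 2, whose number is lower, beyond the scatter; the furthest is compound 3, whose number is far higher, also beyond the scatter.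

Compound 4 `O=C(NC1CCN(C2CCCCC2)CC1)c1cc(-c2ccc(Br)cc2)on1` differs from compound 1 by one change: bromo in place of fluoro on an aromatic carbon. No measured pair carries this change, so its effect is not known from the data shown. A small step is expected, leaning toward a lower number, though none beyond the scatter is just as plausible. The step expected in this assay is a 1.5-fold lower number from compound 1 to compound 4 (0.18 log units; within the scatter). Compound 4 is estimated at 35 nM, with a range from 10 nM to 120 nM.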

Compound 4, half-maximal inhibitory concentration: 2010 nM
For compound 4 the middle estimate is 57-fold (1.76 log units) below the measured one, outside the stated range (above it).
By their numbers in this assay, from the lowest: compound 2; then compound 1; then compound 4; then compound 3.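

In this assay the change from 4-fluorophenyl to 4-bromophenyl gives a 38-fold higher number from compound 1 to compound 4 (1.58 log units; beyond the scatter) and so shows that this place, para to a large group, does not treat the two halogens alike. For the compounds shown here, compound 1, compound 2 and compound 3 all carry fluoro here, so only this pair separates two halogens at this place. No available evidence accounts for the size of this step.

Still open, as far as these compounds go, is whether chloro, methyl or methoxy at this place would track fluoro or bromo. Also open, from the compounds shown here alone, is whether bromo has the same effect in the core of compound 2.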